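From 2-fluorophenyl to 4-fluorophenyl in the series

The source may report more compounds than this note shows. Statements on the series, on what has been measured and on what is new or still open speak of the compounds shown alone.

In a functional assay on A549 cells (Homo sapiens) (a lower number here means that less compound is needed, a higher number that more compound is needed for the effect), compound 1 (`Oc1nc(-c2cccc(F)c2)nc2ccccc12`) gives 9.8 ug/mL. Compound 2 (`COc1cc2nc(-c3ccccc3F)nc(O)c2cc1OC`) is known in this assay only as a limit, < 5 ug/mL, so it has no exact position on the scale. Compound 3 (`COc1cc2nc(-c3ccc(F)cc3)nc(O)c2cc1OC`) has 4-fluorophenyl in place of 2-fluorophenyl on an aromatic carbon. Going by the values given here, no measured pair isolates this change, so no shift beyond the scatter is expected in this assay, and no direction is favoured. The expected size of the change is a step that the limit leaves unreadable from compound 2 to compound 3. Compound 3 is estimated at 4 ug/mL, with an expected range of 1.5 ug/mL to 10 ug/mL.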

Compound 3, concentration for half-maximal effect: > 20 ug/mL
Compound 3 was reported as a limit; the forecaster's own chance of this, stated with the estimate: 50%; middle value at least 5.0-fold (0.69 log units) away from the limit.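

In this assay, 4-fluorophenyl in place of 2-fluorophenyl gives an at least 4.0-fold higher number from compound 2 to compound 3 (0.60 log units; beyond the scatter). Going by these compounds alone, this is the first readable step, and it shows that moving the fluorine within the phenyl group at this position on the shared core is enough to separate two compounds made of the same atoms. Compound 2 and compound 3 are each known only as a limit, so the step has a minimum size but no exact one.

Exact values for both compounds remain open. So does the behaviour of an unsubstituted phenyl, a chlorophenyl or an aminophenyl at this position.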